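The source may report more compounds than this note shows. Statements on the series, on what has been measured and on what is new or still open speak of the compounds shown alone.

Compound 2 `Oc1ccc(-c2cc(-c3cccs3)nc(-c3ccccc3Cl)c2)cc1` carries a 2-chlorophenyl group on the shared core. In an ADME assay on HEK293 cells (Homo sapiens) for cytotoxicity, read by CCK-8 assay and cell counting, with a stated time of 2 days (on this read-out lower numbers stand for stronger inhibition and higher numbers for weaker inhibition), compound 2 gives 5220 nM, the highest of the two numbers obtained. Its nearest neighbour is compound 3 `Oc1ccc(-c2cc(-c3ccco3)nc(-c3ccccc3Cl)c2)cc1`, which in this assay gives 4310 nM; the step of a 1.2-fold lower number from compound 2 to compound 3 (0.08 log units; within the scatter) lies within the scatter. Compound 1 `Oc1ccc(-c2cc(-c3ccccn3)nc(-c3ccccc3Cl)c2)cc1` in this assay gives "not determined" (no result reported), so no number is available for it.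

Compound 4 `Oc1ccc(-c2cc(-c3ccc(Cl)cc3)nc(-c3cccs3)c2)cc1` differs from compound 2 by 4-chlorophenyl in place of 2-chlorophenyl on an aromatic carbon. Within the data shown here, no measured step bears on this change: the single step available exchanges furan-2-yl for thiophen-2-yl and stays within the scatter, so it says nothing about moving from a 2-chlorophenyl to a 4-chlorophenyl group. Among the measured compounds shown here, with only weak readings close together and no step on a chlorophenyl exchange, the expected step is one of no change beyond the scatter, a 1.0-fold lower number from compound 2 to compound 4 (0.02 log units; within the scatter). Compound 4 is therefore estimated at 5000 nM in this assay, with a range from 2200 nM to 11000 nM.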

Compound 4, half-maximal inhibitory concentration: 4520 nM
Estimate against measurement, compound 4: 1.1-fold (0.04 log units) above; the range from low to high includes it.
By their numbers in this assay, from the lowest: compounds 3, 4 and 2 (each within the scatter of the next).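

In this assay, placing 4-chlorophenyl where 2-chlorophenyl stood, on the aromatic carbon next to the ring nitrogen, gives a 1.2-fold lower number from compound 2 to compound 4 (0.06 log units; within the scatter) and so stays as close as the earlier furan-2-yl exchange did. Among these compounds, this is the first step that bears on the chlorophenyl group itself, and with the thiophen-2-yl group held in place, the read-out does not separate the 2-chlorophenyl and 4-chlorophenyl forms. No measurement offered here accounts for this result. Still open, as far as these compounds go, is whether a different group at this position, such as an amine or a carboxylic acid rather than a chlorophenyl ring, would move the number beyond the scatter. Also open, from the compounds shown here alone, is where compound 1 stands, as it has no number to compare.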